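Piperidin-1-yl to diisopropylamino on the thiocarbonyl carbon

This account rests on a few compounds, and the source may have more. Where it says the series, first, only, none or still open, it means among the compounds named here.

Of the compounds shown here, two carry numbers so far. Compound 1 `O=c1cc(CSC(=S)N2CCCCC2)oc2cc(Cl)ccc12` gives 2500 nM in a functional assay on SW480 cells (Homo sapiens) for antiproliferative activity, read by MTT assay, with a stated time of 72 h; on this read-out lower numbers stand for stronger inhibition and higher numbers for weaker inhibition; this is the highest of the two numbers in hand. Compound 2 `O=c1c(Cl)c(CSC(=S)N2CCCCC2)oc2ccccc12` gives 690 nM in this assay. Compound 1 and compound 2 differ at more than one place, so their values stand only side by side, and the gap between them lies beyond the scatter. Within the data shown here, compound 3 `CC(C)N(C(=S)SCc1cc(=O)c2ccc(Cl)cc2o1)C(C)C` has no measurement yet; it differs from compound 1 by a single change, (diisopropylamino in place of piperidin-1-yl on a thiocarbonyl carbon). Both the leaving group and the entering group carry no hydrogen-bond donors, no hydrogen-bond acceptors and no net charge. Among the measured compounds shown here, no step between measured compounds touches this place on the thiocarbonyl carbon, so the numbers in hand give no size and no direction for it. The plainest expectation is therefore no change at the digits printed from compound 1 to compound 3 (within the scatter), a step not beyond the scatter. On that basis compound 3 is estimated at 2500 nM in this assay, with a range from 1000 nM to 6500 nM.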

Compound 3, half-maximal inhibitory concentration: > 25000 nM
Compound 3 ended at the assay's limit; the forecaster's own chance of this, stated with the estimate: 5%; middle value at least 10-fold (1.00 log units) from the limit.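

The place on the thiocarbonyl carbon proves sensitive, which compounds 1 and 2 could not show, since both carry piperidin-1-yl there. In this assay, diisopropylamino in place of piperidin-1-yl gives an at least 10-fold higher number from compound 1 to compound 3 (1.00 log units; beyond the scatter), so this swap between two amine groups on the same core is far from neutral in antiproliferative activity. Compound 3 gives > 25000 nM, which is a limit of the assay and not a number, so the step has a lower bound but no full size: the limit of > 25000 nM in this assay, at which 1 of the 3 values shown sits.

The two groups match in their counts of hydrogen-bond donors and acceptors and in carrying no net charge, yet they differ in that piperidin-1-yl is a ring and diisopropylamino has none, and this single step cannot tell whether the ring itself matters or only the particular open-chain group that replaced it. Groups such as dimethylamino, pyrrolidin-1-yl or morpholin-4-yl would help to separate these readings, and it also remains open whether diisopropylamino has the same effect on the core of compound 2.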